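Swapping the Ring-Nitrogen Substituent of Compound 2

A few compounds are considered here, and "the series" means these few. Any claim that something is new, unique, unknown or untested is made for them only; others in the source may bear on it.

Compound 1 `CCC(C)n1nc(C)cc1NC(=O)Cn1nnc(-c2ccccc2)n1`: in an assay on HEK293 cells for activation of Kir3.1/Kir3.2 (Homo sapiens), read by thallium flux (on this read-out lower numbers stand for an effect already at smaller amounts and higher numbers for an effect only at larger amounts of compound), compound 1 gives only a limit, > 5000 nM
Compound 2 `Cc1cc(NC(=O)Cn2nnc(-c3ccccc3)n2)n(C2CCS(=O)(=O)CC2)n1`: in this assay compound 2 gives only a limit, > 10000 nM

Among the measured compounds shown here, compound 2 therefore stands at a limit, as does the one other value shown. The step that the two limits leave unreadable from compound 1 to compound 2 cannot be sized, since both ends rest on limits: the limit of > 10000 nM in this assay, at which 1 of the 2 values shown sits, and (the limit of > 5000 nM in this assay, at which 1 of the 2 values shown sits). Compound 3 `Cc1cc(NC(=O)Cn2nnc(-c3ccccc3)n2)n(CC2CCCCC2)n1` has not been measured. It differs from compound 2 by cyclohexylmethyl in place of 1,1-dioxothian-4-yl on an aromatic nitrogen. For the measured compounds named here, no measured step bears on this exchange, and both values that might anchor it are limits, so the expected outcome is that compound 3 behaves like compound 2 and most likely again yields a limit rather than a number. The step of an at least 1.1-fold lower number from compound 2 to compound 3 (0.04 log units; that floor lies within the scatter) is accordingly estimated to lie within the scatter. Compound 3 is estimated at 9000 nM, with a range from 2000 nM to 40000 nM.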

Compound 3, half-maximal effective concentration: 176 nM
Compound 3: the middle estimate sits 51-fold (1.71 log units) above what was measured; the measured number lies below the stated range.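

In this assay the substituent on the aromatic nitrogen decides whether these compounds give a number at all: cyclohexylmethyl brings an at least 56-fold lower number from compound 2 to compound 3 (1.75 log units; beyond the scatter) in place of 1,1-dioxothian-4-yl, and an at least 28-fold lower number from compound 1 to compound 3 (1.45 log units; beyond the scatter) in place of sec-butyl. The first step is only a floor, for compound 2 stands at a limit: the limit of > 10000 nM in this assay, at which 1 of the 3 values shown sits. The second step is also only a floor, for compound 1 stands at a limit: the limit of > 5000 nM in this assay, at which 1 of the 3 values shown sits.

The compounds shown leave open whether the carbon ring of cyclohexylmethyl or the single carbon linking it to the aromatic nitrogen matters more, as a cyclohexyl group attached directly would show. They also leave open whether a benzyl group, a longer chain such as n-hexyl, or a piperidin-4-yl amine would be tolerated at this position.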